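The source may report more compounds than this note shows. Statements on the series, on what has been measured and on what is new or still open speak of the compounds shown alone.

Three compounds built on a shared core have been examined in an ADME assay on Vero cells (Chlorocebus sabaeus) for cytotoxicity, read by resazurin assay, with a stated time of 3 days (a higher number here means a weaker inhibitor, a lower number a stronger inhibitor), and a fourth awaits its reading. Compound 1, with the structure `CCCCOC(=O)Nc1cc2nc(C3CCCCC3)[nH]c2cc1N(C)C`, carries a dimethylamino group and a butoxy group on its carbonyl carbon. In this assay compound 1 gives > 100 ug/mL, which is a limit of the assay rather than a number. Compound 2, with the structure `CCCCOC(=O)Nc1cc2nc(C3CCCCC3)[nH]c2cc1N(CC)CC`, differs from compound 1 by diethylamino in place of dimethylamino on an aromatic carbon. In this assay compound 2 gives > 100 ug/mL, again a limit. Compound 3, with the structure `CN(C)c1cc2[nH]c(C3CCCCC3)nc2cc1NC(=O)c1cccc(Br)c1`, differs from compound 1 by 3-bromophenyl in place of butoxy on a carbonyl carbon. In this assay compound 3 gives > 100 ug/mL, which is also a limit.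

Because all three values sit at the limit of > 100 ug/mL in this assay, at which 3 of the 3 values shown sit, the step that the two limits leave unreadable from compound 1 to compound 2 cannot be sized, and the same holds for the step that the two limits leave unreadable from compound 1 to compound 3.

Compound 4, with the structure `CCN(CC)c1cc2[nH]c(C3CCCCC3)nc2cc1NC(=O)c1cccc(Br)c1`, is not yet measured. It differs from compound 3 by diethylamino in place of dimethylamino on an aromatic carbon. This is the same kind of change as that from compound 1 to compound 2, though the place differs: in compound 3 the group sits ortho to a large group, whereas in compound 1 it sits ortho to a (butoxycarbonyl)amino group.

In this assay the step from compound 3 to compound 4 is expected to be a step that the limit leaves unreadable from compound 3 to compound 4, resting on compound 1 and compound 2 both sitting at the limit of > 100 ug/mL in this assay, at which 3 of the 3 values shown sit. Compound 4 is therefore estimated at 200 ug/mL, most likely reported again as a limit, with a plausible span from 80 ug/mL to 500 ug/mL.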

Compound 4, half-maximal inhibitory concentration: > 100 ug/mL
Compound 4 was reported as a limit; the forecaster's own chance of this, stated with the estimate: 85%; the middle value does not contradict the limit.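

In this assay compound 4 gives > 100 ug/mL, which is a limit of the assay. The steps from compound 3 to compound 4 and from compound 2 to compound 4 therefore cannot be read: the limit of > 100 ug/mL in this assay, at which 4 of the 4 values shown sit. The compounds shown leave open whether diethylamino in place of dimethylamino, or 3-bromophenyl in place of butoxy, changes the reading in this assay at all.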